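The source may hold more compounds than are shown below. What is called first, only, known or untested is meant among the compounds shown, and "the series" means these compounds.

The three measured compounds share a core in which one aromatic amide is joined through a benzylic nitrogen to a second aromatic ring, and they differ in the groups on the two outer rings. Compound 1 `O=C(O)c1ccc(CNC(=O)c2cccc(-c3ccccc3)c2)cc1` gives 670 nM in an assay on HeLa cells with Bile acid receptor (Homo sapiens) as the target, read by a luciferase reporter, with a stated time of 24 h; a higher number here means that more compound is needed for the effect, a lower number that less compound is needed. Compound 2 `CC(C)(C)c1ccc(C(=O)NCc2ccc(NC(=O)C(F)(F)F)cc2Cl)cc1` gives 14 nM in this assay. Compound 3 `CN(C)C(=O)c1ccc(CNC(=O)c2ccc(C(C)(C)C)cc2)cc1` gives 170 nM in this assay, which places it second highest of the three: compound 1 sits higher and compound 2 sits lower, and both gaps lie beyond the usual scatter.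

Compound 4 `CC(C)(C)c1ccc(C(=O)NCc2ccc(S(C)(=O)=O)cc2)cc1` has not yet been measured. It differs from compound 3 in one place: methylsulfonyl in place of dimethylcarbamoyl on an aromatic carbon. Among the measured compounds shown here, no measured pair shows this change on its own, so nothing beyond the scatter is expected in either direction, and the estimated step of a 1.2-fold higher number from compound 3 to compound 4 (0.07 log units; within the scatter) is small. Compound 4 is therefore expected to give about 200 nM in this assay, with a likely range from 60 nM to 700 nM.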

Compound 4, half-maximal effective concentration: 3800 nM
The estimate for compound 4 lay 19-fold (1.28 log units) below the measured number; measured number outside the range, above it.
By their numbers in this assay, from the lowest: compound 2; then compound 3; then compound 1; then compound 4.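

Replacing dimethylcarbamoyl with methylsulfonyl on an aromatic carbon, para to a large group, gives a 22-fold higher number from compound 3 to compound 4 (1.35 log units; beyond the scatter) in this assay and is the first change among these compounds that can be read on its own. The step is large and beyond the scatter, so this position distinguishes the two groups, although neither contains a ring, a hydrogen-bond donor or a net charge. No measurement here explains the size of this step.

The compounds shown leave open how a nitrile, an amine or a sulfonamide bearing a free amino group would read at this position. They also leave open whether the same change would give a step of similar size with a different group on the other outer ring.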